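The source may hold more compounds than are shown below. What is called first, only, known or untested is meant among the compounds shown, and "the series" means these compounds.

In a functional assay on HepG2 cells (Homo sapiens) for antiproliferative activity, read by fluorescence and resazurin assay, with a stated time of 48 h (a lower number here means a stronger inhibitor, a higher number a weaker inhibitor), compound 1 `CCOc1ccc(NC(=O)c2cc3cc(Br)ccc3oc2=O)cc1` gives 37000 nM and compound 2 `Cc1noc(NS(=O)(=O)c2ccc(NC(=O)c3cc4cc([N+](=O)[O-])ccc4oc3=O)cc2)c1C` gives 15000 nM. Compound 2 therefore holds the lower of the two numbers, and the gap between them lies beyond the usual scatter. Compound 3 `CCOc1ccc(NC(=O)c2cc3cc([N+](=O)[O-])ccc3oc2=O)cc1` differs from compound 2 in one place: ethoxy in place of (3,4-dimethyl-1,2-oxazol-5-yl)sulfamoyl on an aromatic carbon. Going by the values given here, no measured pair shows this change on its own, so the evidence for the size of the step in this assay is thin. A modest move to a higher number, meaning a weaker inhibitor, is expected because compound 1 with the same ethoxy gives 37000 nM. The estimated step is a 1.6-fold higher number from compound 2 to compound 3 (0.20 log units; within the scatter). For compound 3 the expected value is 24000 nM, with an estimated range of 8000 nM to 60000 nM.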

Compound 3, half-maximal inhibitory concentration: 28300 nM
Estimate against measurement, compound 3: 1.2-fold (0.07 log units) below; the measured number falls inside the stated range.
By their numbers in this assay, from the lowest: compounds 2, 3 and 1 (each within the scatter of the next, the first and the last beyond it).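

In this assay, ethoxy in place of the much larger (3,4-dimethyl-1,2-oxazol-5-yl)sulfamoyl group gives a 1.9-fold higher number from compound 2 to compound 3 (0.28 log units; within the scatter) and so removes a five-membered aromatic ring and a hydrogen-bond donor without a step beyond the scatter. Going by these compounds alone, compound 3 also gives the first one-place comparison at the other end of the molecule, where nitro in place of bromo gives a 1.3-fold lower number from compound 1 to compound 3 (0.12 log units; within the scatter) and is likewise not separable from the scatter. Nothing measured here explains either step.

From the compounds shown here alone, whether an amine or a carboxylic acid on that same aromatic carbon would move the number beyond the scatter remains open. So does the outcome of replacing the nitro with an amine, and all three compounds remain weak inhibitors in this assay's micromolar range.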